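Exchange of one aryl group on a saturated ring carbon

The compounds below may be only part of what the source reports. "The series", "measured", "known", "first", "only" and "open" are said of these compounds alone.

Of the compounds shown here, three of a shared core have been measured in a functional assay on the whole organism (strain albino) for inhibition, with Rattus norvegicus as the target, read by paw edema, with stated times of 30 min and 2 h, at a dose of 100 mg/kg by the oral route; a lower number here means less inhibition, a higher number more inhibition at the dose given (going by the name of the read-out). Compound 1 `COc1ccc(C2=NN(C(=O)C(C)Br)C(c3c(Cl)cccc3Cl)C2)cc1OC` gives 56%, compound 2 `COc1ccc(C2=NN(C(=O)C(C)O[N+](=O)[O-])C(c3ccco3)C2)cc1OC` gives 39%, and compound 3 `COc1ccc(C2CC(c3ccc(OC)c(OC)c3)=NN2C(=O)C(C)O[N+](=O)[O-])c(OC)c1` gives 61%. Compound 3 thus carries the highest of the three numbers, but its gap to compound 1 lies within the scatter, and only compound 2 stands clearly lower. For the measured compounds named here, the one step that differs in a single place, a number 22 percentage points higher from compound 2 to compound 3 (beyond the scatter), shows that the group on the saturated ring carbon can move the read-out by a modest amount.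

Compound 4 `COc1ccc(C2=NN(C(=O)C(C)O[N+](=O)[O-])C(c3c(Cl)cccc3Cl)C2)cc1OC` is not yet measured. It differs from compound 3 in that same place: 2,6-dichlorophenyl in place of 2,4-dimethoxyphenyl on a saturated ring carbon. Going by the values given here, no measured step covers this exact exchange. Compound 1, however, already bears a 2,6-dichlorophenyl group on a saturated ring carbon and differs from compound 3 elsewhere as well; the values of compound 1 and compound 3 lie within the scatter of each other. On that basis the step from compound 3 to compound 4 is expected to be small, a number 6 percentage points lower from compound 3 to compound 4 (within the scatter), within the scatter. Compound 4 is therefore estimated at 55%, with a range from 40% to 70%.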

Compound 4, a percentage reported as inhibition, in the whole organism at one dose (the size of the read-out at that dose, not a potency): 53%
For compound 4 the middle estimate is 2 percentage points above the measured one, and the stated range covers the measured number.
By their numbers in this assay, from the lowest: compound 2; then compounds 4, 1 and 3 (each within the scatter of the next).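

In this assay, with the nitrooxy group held fixed, the exchange on the saturated ring carbon now has three members: 2,6-dichlorophenyl in place of 2,4-dimethoxyphenyl gives a number 8 percentage points lower from compound 3 to compound 4 (within the scatter), and 2,6-dichlorophenyl in place of furan-2-yl gives a number 14 percentage points higher from compound 2 to compound 4 (beyond the scatter). Together with the earlier step, this shows that the two substituted phenyl groups cannot be told apart at this position, despite their different substituents, while the furan-2-yl compound stands clearly apart from both. For the compounds shown here, the new compound also gives the first comparison at the other position, where nitrooxy in place of bromo on the saturated chain carbon, with 2,6-dichlorophenyl on the ring, gives a number 3 percentage points lower from compound 1 to compound 4 (within the scatter), so in this pair the exchange of these two groups is not resolved by the read-out.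

As far as these compounds go, whether that holds with furan-2-yl or 2,4-dimethoxyphenyl on the ring carbon remains open, as does the outcome with an amine or a carboxylic acid on the chain carbon, or with a cyclohexyl group on the ring carbon. Nothing shown here offers an explanation for the lower furan-2-yl result.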